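Dropping a methoxy group: what binding to expect

This account rests on a few compounds, and the source may have more. Where it says the series, first, only, none or still open, it means among the compounds named here.

Measured so far:
compound 1 `Cc1ccc(-c2n[nH]cc2N2CCCNCC2)cc1` — 3590 nM
compound 2 `COc1cccc(-c2n[nH]cc2N2CCCNCC2)c1` — > 10000 nM

In an assay on isolated protein for binding affinity to 5-hydroxytryptamine receptor 1B (Homo sapiens) (on this read-out higher numbers stand for weaker inhibition and lower numbers for stronger inhibition), compound 1 gives 3590 nM. For compound 2 the result is not a number but a limit of the assay, > 10000 nM. As far as these compounds go, compound 2 therefore stands at the limit of > 10000 nM in this assay, at which 1 of the 2 values shown sits, and how far its binding actually lies beyond that point is unknown.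

Compound 3 `c1ccc(-c2n[nH]cc2N2CCCNCC2)cc1` has not been measured yet. It differs from compound 2 by hydrogen in place of methoxy on an aromatic carbon, in plain words hydrogen in place of methoxy on an aromatic carbon. Because compound 2 is known only as a limit, the size of the step to compound 3 cannot be measured against a fixed starting value. Still, compound 1, which carries a methyl on the same kind of ring and gives 3590 nM, shows that a measurable value is reachable in this series. The expected step of an at least 2.0-fold lower number from compound 2 to compound 3 (0.30 log units; that floor lies within the scatter) points toward stronger binding than the limit. Compound 3 is estimated at 5000 nM, with a range from 1500 nM to 20000 nM.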

Compound 3, inhibition constant: > 10000 nM
Compound 3 gave a limit, no number; the forecaster's own chance of this, stated with the estimate: 30%; middle value at least 2.0-fold (0.30 log units) from the limit.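

Removing the methoxy group does not bring a measurable value in this assay: compound 3, like compound 2, ends at a limit of the assay, and the step between them cannot be read because neither end is a number: the limit of > 10000 nM in this assay, at which 2 of the 3 values shown sit. The methyl group gives the readable result, as hydrogen in its place produces an at least 2.7-fold higher number from compound 1 to compound 3 (0.44 log units; beyond the scatter), which means weaker binding. Among the three compounds, only compound 1, with its methyl, gives a number.

As far as these compounds go, how far compound 2 and compound 3 lie beyond the limit remains unknown, so they cannot be placed in order. Also open, from the compounds shown here alone, is whether an ethyl group or a chlorine atom in place of that methyl would give a lower number than compound 1 does.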